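Ring change on a carbonyl carbon of compound 2

A few compounds are considered here, and "the series" means these few. Any claim that something is new, unique, unknown or untested is made for them only; others in the source may bear on it.

In an in vitro ADME assay on microsomes from liver (Homo sapiens) for pharmacokinetics (a lower number here means slower removal, a higher number faster removal of the compound), compound 1 `CCN1CC[C@H](NC(=O)C[C@@H]2C(=O)NC=CN2S(=O)(=O)c2ccc(C)cc2)C(C)(C)C1` gives < 50 mL.min-1.g-1, which is a limit of the assay and not a number. For the measured compounds named here, compound 2 `Cc1cc(S(=O)(=O)N2C=CNC(=O)[C@H]2CC(=O)N2CC[C@H](N3CCCC3)C2)c(C)cc1Cl` gives 265 mL.min-1.g-1, the only true number so far. Compound 3 `Cc1cc(S(=O)(=O)N2C=CNC(=O)[C@H]2CC(=O)N2CCCC(N(C)C)CC2)c(C)cc1Cl` differs from compound 2 in one place, on a carbonyl carbon: a group of 10 heavy atoms (8 carbon, 2 nitrogen; one seven-membered non-aromatic ring with 1 hetero atom) in place of a group of 10 heavy atoms (8 carbon, 2 nitrogen; 2 five-membered non-aromatic rings with 1 hetero atom each), on a carbonyl carbon. One seven-membered non-aromatic ring with 1 hetero atom thus takes the place of 2 five-membered non-aromatic rings with 1 hetero atom each, at an equal count of 10 heavy atoms. Going by the values given here, no measured pair shows this kind of change. In this assay no step beyond the scatter is expected, in either direction, and the expectation rests on compound 2 at 265 mL.min-1.g-1. The estimated step runs a 1.2-fold lower number from compound 2 to compound 3 (0.08 log units; within the scatter). For compound 3 the estimated value is 220 mL.min-1.g-1, with an expected range from 100 mL.min-1.g-1 to 450 mL.min-1.g-1.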

Compound 3, intrinsic clearance in microsomes: 64 mL.min-1.g-1
The estimate for compound 3 lay 3.4-fold (0.54 log units) above the measured number, and the stated range ends above it.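

In this assay, for the compounds shown here, the change on the carbonyl carbon gives the first readable one-place step: a 4.1-fold lower number from compound 2 to compound 3 (0.62 log units; beyond the scatter). This position is therefore not indifferent to ring make-up, since one seven-membered non-aromatic ring with 1 hetero atom and 2 five-membered non-aromatic rings with 1 hetero atom each separate in this read-out despite equal counts of heavy atoms, hydrogen-bond donors and acceptors, and the same net charge. Nothing shown bears on the cause of this step.

Going by these compounds alone, compound 1 gives < 50 mL.min-1.g-1, a limit of the assay and not a number, so it supports no step. Still open, going by these compounds, is whether the step belongs to the seven-membered ring or to the loss of the defined stereocentre, and how a piperidine on the same carbonyl carbon would read.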